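The source may hold more compounds than are shown below. What is called first, only, known or untested is meant among the compounds shown, and "the series" means these compounds.

Measured so far in a physicochemical assay (Homo sapiens) for solubility, with a stated time of 18 h, at pH 7.4; on this read-out lower numbers stand for lower solubility and higher numbers for higher solubility:

- compound 1, `CN1CCN(c2ccc(/C=C3/SC(Nc4ccccc4)=NC3=O)cc2)CC1`: 0.35 ug/mL
- compound 2, `CN(C)c1ccc(/C=C2/SC(Nc3ccc(Oc4ccccc4)cc3)=NC2=O)cc1`: 0.01 ug/mL

Compound 2 holds the lowest of the two numbers; compound 1 lies above it by a margin well beyond the scatter. Among the compounds with values here, no pair differing in a single place has been measured, so no single step is established.

Compound 3, `O=C1N=C(Nc2ccc(Oc3ccccc3)cc2)S/C1=C/c1ccc(N2CCNCC2)cc1`, differs from compound 2 by piperazin-1-yl in place of dimethylamino on an aromatic carbon. The piperazin-1-yl group brings one hydrogen-bond donor and two hydrogen-bond acceptors where dimethylamino carried none and one; the rest of compound 2 is kept. Compound 1 also carries a six-membered non-aromatic ring with two hetero atoms at the same kind of position and gives the higher of the two values, though it lacks the phenoxy group of compound 2, so the comparison is indirect.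

For compound 3 the step of a 15-fold higher number from compound 2 to compound 3 (1.18 log units; beyond the scatter) is expected to point upward, beyond the scatter, on the basis of compound 1 at 0.35 ug/mL against compound 2 at 0.01 ug/mL. Compound 3 is estimated at 0.15 ug/mL, within 0.03 ug/mL to 1 ug/mL.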

Compound 3, solubility: 0.1 ug/mL
Compound 3: the middle estimate sits 1.5-fold (0.18 log units) above what was measured, and the stated range covers the measured number.
By their numbers in this assay, from the lowest: compound 2; then compound 3; then compound 1.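

In this assay the change of dimethylamino to piperazin-1-yl on an aromatic carbon, para to a large group, gives a single-place step (a 10-fold higher number from compound 2 to compound 3 (1.00 log units; beyond the scatter)) that lies beyond the scatter. With the phenoxy group and the rest of compound 2 kept, this position is now shown to be one where a change of this one group alone moves the read-out, something the earlier pair could not show because compound 1 and compound 2 differ in more than one place. No measurement at hand bears on which feature of the entering group accounts for the step.

The compounds shown leave open whether the step depends on the ring itself or on the hydrogen-bond donor that enters with it, a question that morpholine, a ring without that donor, or an open-chain amine at the same position could address. They also leave open whether the same change would give a step of similar size on a core without the phenoxy group, and how a carboxylic acid at this position would compare.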